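Compound 3 to compound 4: piperidin-1-yl replaces 1,3-benzoxazol-2-yl

This account rests on a few compounds, and the source may have more. Where it says the series, first, only, none or still open, it means among the compounds named here.

In a toxicity assay on NIH3T3 cells (Mus musculus) for cytotoxicity, read by resazurin assay (a higher number here means that more compound is needed for the effect, a lower number that less compound is needed), compound 3 `c1ccc(-c2ccc(Cn3cncc3CNc3ccc(-c4nc5ccccc5o4)c(-c4ccccc4)c3)cc2)cc1` gives > 10000 nM, which is a limit and not a number. That places compound 3 at the limit of > 10000 nM in this assay, at which 2 of the 3 values shown sit. Compound 2 `CC(C)OC(=O)c1ccc(NCc2cncn2Cc2ccc(-c3ccccc3)cc2)cc1-c1ccccc1` gives > 10000 nM, also a limit. Compound 1 `CN(C)c1ccc(NCc2cncn2Cc2ccc(-c3ccccc3)cc2)cc1-c1ccccc1` gives > 1000 nM, again a limit, and it alone stands at the limit of > 1000 nM in this assay, at which 1 of the 3 values shown sits.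

Compound 4 `c1ccc(-c2ccc(Cn3cncc3CNc3ccc(N4CCCCC4)c(-c4ccccc4)c3)cc2)cc1` carries piperidin-1-yl in place of 1,3-benzoxazol-2-yl on an aromatic carbon.

For the measured compounds named here, three measured steps bear on this change at the same place: a step that the two limits leave unreadable from compound 1 to compound 3, a step that the two limits leave unreadable from compound 2 to compound 3 and a step that the two limits leave unreadable from compound 1 to compound 2. None of them has a readable size, so they fix neither a size nor a direction. Compound 1, with dimethylamino at this place, is the nearest comparison for the entering group, and its > 1000 nM is only a limit. A modest move towards less compound needed is therefore expected, though a result at the limit remains likely: an at least 1.6-fold lower number from compound 3 to compound 4 (0.22 log units; that floor lies within the scatter). For compound 4 the estimate is 6000 nM, with an expected range of 1500 nM to 20000 nM.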

Compound 4, half-maximal effective concentration: > 1000 nM
Compound 4 gave a limit, no number; the forecaster's own chance of this, stated with the estimate: 75%; the middle value lies beyond the limit too.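

In this assay compound 4 gives > 1000 nM, a limit and not a number. For the compounds shown here, compound 1, compound 2, compound 3 and compound 4 all carry limits, so no step among them can be read. The compounds shown leave open whether exchanging the group at this place shifts the concentration needed for cytotoxicity, and in which direction.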